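The compounds below may be only part of what the source reports. "The series", "measured", "known", "first", "only" and "open" are said of these compounds alone.

Measured compounds:
compound 1, `O=S(=O)(Nc1ccccc1)c1ccccc1`, 9.1
compound 2, `O=S(=O)(Nc1ccccc1)c1ccc(Br)cc1`, 8.5

The two measured compounds share one core and differ only on the ring that carries the sulfonyl group. In an ADME assay, compound 1 gives 9.1, the higher of the two numbers, and compound 2 gives 8.5. Going by the values given here, the single measured step, a number 0.60 log units lower from compound 1 to compound 2 (beyond the scatter), came with bromo in place of hydrogen on an aromatic carbon of that ring.

Compound 3, `O=[N+]([O-])c1cccc(S(=O)(=O)Nc2ccccc2)c1`, has not yet been measured in this assay. Relative to compound 1 the change is nitro in place of hydrogen on an aromatic carbon of a six-membered aromatic ring of carbon only, meta to a large group. Among the compounds with values here, the only step that bears on it is the one from compound 1 to compound 2, which was modest and went downward. Because compound 2 showed a number 0.60 log units lower from compound 1 to compound 2 (beyond the scatter), a change on the same ring, a step downward beyond the scatter is expected for compound 3 as well. The expected step is a number 1.10 log units lower from compound 1 to compound 3 (beyond the scatter). Compound 3 is therefore estimated at 8, with a range from 7.6 to 8.4.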

Compound 3, acid dissociation constant: 7.5
Estimate against measurement, compound 3: 0.50 log units above; the measured number lies below the stated range.
By their numbers in this assay, from the lowest: compound 3; then compound 2; then compound 1.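

In this assay, going by these compounds alone, nitro in place of hydrogen on an aromatic carbon, meta to a large group, gives a number 1.60 log units lower from compound 1 to compound 3 (beyond the scatter), a step of large size, whereas the only earlier step, a number 0.60 log units lower from compound 1 to compound 2 (beyond the scatter), was modest. The ring that carries the sulfonyl group can therefore support a large downward step as well as a modest one, and this position, meta to a large group, is now shown to be one where a single change can produce such a step. Nothing in the available data explains why the nitro step is this large.

The compounds shown leave open whether a methoxy group, an amine or a carboxylic acid in this same position would also lower the number, leave it within the scatter or raise it. They also leave open whether nitro elsewhere on this ring, or on the other aromatic ring of the shared core, would give a step of similar size.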